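The compounds below may be only part of what the source reports. "The series", "measured", "known", "first", "only" and "open" are said of these compounds alone.

Compound 1 `CC(=O)OC[C@H]1O[C@@H](n2cc(CN3C(=O)/C(=C/c4ccc(C)cc4)c4ccccc43)nn2)[C@H](OC(C)=O)[C@@H](OC(C)=O)[C@@H]1OC(C)=O` and compound 2 `CC(=O)OC[C@H]1O[C@@H](n2cc(CN3C(=O)/C(=C/c4cccs4)c4ccccc43)nn2)[C@H](OC(C)=O)[C@@H](OC(C)=O)[C@@H]1OC(C)=O` share one core and differ only in the group on a double-bonded chain carbon bound to a double-bonded ring carbon. In a functional assay on HeLa cells (Homo sapiens) for cytotoxicity, read by sulforhodamine B assay, with a stated time of 48 h (on this read-out higher numbers stand for weaker inhibition and lower numbers for stronger inhibition), compound 1 gives 85600 nM, while in this assay compound 2 gives 36900 nM. Within the data shown here, the step of a 2.3-fold lower number from compound 1 to compound 2 (0.37 log units; beyond the scatter) is the only measured step so far. Compound 2 therefore holds the lowest of the two numbers, with compound 1 the nearest and higher of them.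

Compound 3 `CCC/C=C1/C(=O)N(Cc2cn([C@@H]3O[C@H](COC(C)=O)[C@@H](OC(C)=O)[C@H](OC(C)=O)[C@H]3OC(C)=O)nn2)c2ccccc21` keeps everything of compound 2 except that (propyl in place of thiophen-2-yl on a double-bonded chain carbon bound to a double-bonded ring carbon). Among the measured compounds shown here, only the step from compound 1 to compound 2 bears on this change, and it was modest in size; it exchanged one aromatic ring for another, whereas here the ring gives way to a chain, so it offers no direct guide to the direction. The analyst expects a step of modest size a 1.6-fold higher number from compound 2 to compound 3 (0.21 log units; within the scatter), and no direction that can be called firm beyond the scatter. Compound 3 is estimated at 60000 nM, with a range from 20000 nM to 180000 nM.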

Compound 3, half-maximal inhibitory concentration: > 100000 nM
Compound 3 was reported as a limit; the forecaster's own chance of this, stated with the estimate: 10%; at least 1.6-fold (0.22 log units) between middle value and limit.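

Compound 3 is known only as a limit: the limit of > 100000 nM in this assay, at which 1 of the 3 values shown sits. Even so, in this assay the exchange of the ring for a chain can be read, since propyl in place of thiophen-2-yl on a double-bonded chain carbon bound to a double-bonded ring carbon gives an at least 2.7-fold higher number from compound 2 to compound 3 (0.43 log units; beyond the scatter), so this place does respond to a change from a five-membered aromatic ring to an open chain, and compound 2 keeps the lowest number of the three. Propyl in place of 4-methylphenyl at the same place gives an at least 1.1-fold higher number from compound 1 to compound 3 (0.06 log units; that floor lies within the scatter), so the floor of this step does not separate the two, and the chain cannot be ranked against the six-membered aromatic ring.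

The compounds shown leave open whether the lower number of compound 2 goes with the sulfur atom or with the five-membered aromatic ring as such, which a furan-2-yl group at this place would help to separate. Also open, from the compounds shown here alone, is how a longer chain such as hexyl, or a propyl chain ending in an amine, would read here, and whether any group at this place would move the numbers far from those of compound 2.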